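The compounds below may be only part of what the source reports. "The series", "measured", "known", "first", "only" and "open" are said of these compounds alone.

Measured so far:
compound 1 `CC(C)c1nc(C(=O)NCC2CCN(C3CCC3)CC2)c2ccccn12`: 20%
compound 2 `CCN1CCC(NC(=O)c2nc(C(C)C)n3ccccc23)CC1`: 100%

In a functional assay on CHO cells for agonist activity at 5-hydroxytryptamine receptor 4 (Homo sapiens), read by a luciferase reporter and cAMP accumulation, with a stated time of 4 h (a higher number here means a larger maximal response, a lower number a smaller maximal response), compound 2 gives 100%, the higher of the two numbers; the gap to compound 1 lies beyond the scatter. The two differ in more than one place, so only the values themselves can be compared.

Compound 3 `CC(C)c1nc(C(=O)NC2CCN(CC3(O)CCOCC3)CC2)c2ccccn12` is not yet measured. It differs from compound 2 as follows: 4-hydroxyoxan-4-yl in place of methyl on a saturated chain carbon bound to an amine nitrogen in a ring. Going by the values given here, no measured pair isolates this change, so its size is open; in this assay a moderate downward step from compound 2 is expected, with none beyond the scatter also possible. For compound 3 the expected maximal response in this assay is 75%, ranging from 35% to 105%. The expected step is a number 25 percentage points lower from compound 2 to compound 3 (beyond the scatter).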

Compound 3, largest response reached (Emax), in percent of the reference or control that the assay uses: 72%
Beside the measured number, compound 3's estimate is 3 percentage points above it; measured number inside the range.
By their numbers in this assay, from the lowest: compound 1; then compound 3; then compound 2.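

In this assay, going by these compounds alone, the one step that isolates a single change at this position reads a number 28 percentage points lower from compound 2 to compound 3 (beyond the scatter), with 4-hydroxyoxan-4-yl in place of methyl on a saturated chain carbon bound to an amine nitrogen in a ring. The position therefore accepts this much larger ring-bearing group with a real loss, yet compound 3 still reaches 72% in this series. No evidence bears on what lies behind the drop. The compounds shown leave open which part of the 4-hydroxyoxan-4-yl group carries the step, and whether a cyclohexyl or 4-hydroxycyclohexyl group in its place would give a similar response.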